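Trimming the amide aryl group of compound 1

The compounds below may be only part of what the source reports. "The series", "measured", "known", "first", "only" and "open" are said of these compounds alone.

Compound 1 `Cc1ccc(NC(=O)CN2CCN(c3nnc(Cc4ccncc4)c4ccccc34)CC2)c(C)c1` stands lowest of the three measured numbers: in a functional assay on HT-29 cells (Homo sapiens) for cytotoxicity, read by MTT assay, with a stated time of 72 h (on this read-out higher numbers stand for weaker inhibition and lower numbers for stronger inhibition), compound 1 gives 1930 nM. Compound 2 `COc1ccc(NC(=O)CN2CCN(c3nnc(Cc4ccccc4)c4ccccc34)CC2)cc1OC` gives 145000 nM in this assay, and compound 3 `O=C(CN1CCN(c2nnc(Cc3ccccc3)c3ccccc23)CC1)Nc1cc(C(F)(F)F)ccc1Cl` gives 66800 nM. Compounds 2 and 3 each differ from compound 1 in two places, so their wide gaps to compound 1 cannot be assigned to one change alone. For the measured compounds named here, the only single-change step available, a 2.2-fold lower number from compound 2 to compound 3 (0.34 log units; beyond the scatter), replaces the whole aryl group on the amide-type nitrogen and still moves the number only modestly.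

Compound 4 `Cc1ccccc1NC(=O)CN1CCN(c2nnc(Cc3ccncc3)c3ccccc23)CC1` is the unmeasured member. It differs from compound 1 by hydrogen in place of methyl on an aromatic carbon; read one bond further out, this is 2,4-dimethylphenyl to 2-methylphenyl on the amide-type nitrogen. Since a full swap of that aryl group gave only a modest step, the loss of a single methyl from it is expected to give at most a small rise in this assay, likely within the scatter, which is written as a 1.5-fold higher number from compound 1 to compound 4 (0.16 log units; within the scatter). Compound 4 is therefore estimated at 2800 nM, with a range from 1100 nM to 7000 nM.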

Compound 4, half-maximal inhibitory concentration: 15000 nM
Compound 4: the middle estimate sits 5.4-fold (0.73 log units) below what was measured; the whole stated range lies below it.
By their numbers in this assay, from the lowest: compound 1; then compound 4; then compound 3; then compound 2.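

Removing one methyl from the 2,4-dimethylphenyl group gives a 7.8-fold higher number from compound 1 to compound 4 (0.89 log units; beyond the scatter) in this assay, a larger step than the replacement of the whole aryl group in a 2.2-fold lower number from compound 2 to compound 3 (0.34 log units; beyond the scatter). The change takes away a single carbon and no hydrogen-bond donor or acceptor, yet this aromatic carbon, para to a large group and meta to a methyl group, clearly matters to the read-out in the pair of compound 1 and compound 4. The modest aryl swap therefore gives no safe guide to this position, since compound 2 and compound 3 differ from this pair elsewhere as well, and the two steps stand on different backgrounds.

Nothing at hand bears on why the methyl has this effect. The compounds shown leave open whether an ethyl, a methoxy or a chlorine on this same carbon would match the methyl of compound 1, and whether adding a methyl at this carbon would give a step of similar size on the background shared by compound 2 and compound 3.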